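Taking the Methyl Group off Compound 3

The compounds below may be only part of what the source reports. "The series", "measured", "known", "first", "only" and "open" are said of these compounds alone.

In an ADME assay on MDBK cells (Bos taurus) for cytotoxicity, read by MTT assay, with a stated time of 72 h (a lower number here means that less compound is tolerated, a higher number that more compound is tolerated), compound 3 (`Cc1ccc(NCc2cn(-c3ccccc3)nc2-c2ccc(Br)cc2)cc1`) gives > 100000 nM, which is a limit of the assay and not a number. Compound 1 (`Cc1ccc(-c2nn(-c3ccccc3)cc2CNc2ccccc2)cc1`) gives > 100000 nM, which is also a limit. Compound 2 (`Brc1ccc(NCc2cn(-c3ccccc3)nc2-c2ccc(Br)cc2)cc1`) gives > 100000 nM, likewise a limit. Compound 3 therefore has no exact position in the series, and the data amount to the limit of > 100000 nM in this assay, at which 3 of the 3 values shown sit.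

The next compound, compound 4 (`Brc1ccc(-c2nn(-c3ccccc3)cc2CNc2ccccc2)cc1`), has hydrogen in place of methyl on an aromatic carbon, para to a large group: hydrogen in place of methyl on an aromatic carbon. In this way, 4-methylphenyl becomes phenyl and (4-methylphenyl)amino becomes anilino. The measured step that bears on this change is a step that the two limits leave unreadable from compound 2 to compound 3, with methyl in place of bromo on an aromatic carbon. It offers no size to carry over. Compound 1 already holds the anilinomethyl group, and its result is a limit too.

No step beyond the usual scatter is expected in this assay in either direction, because the limit of > 100000 nM in this assay, at which 3 of the 3 values shown sit, gives no sign of a measurable change. The estimate for this change is a number no higher from compound 3 to compound 4 (the limit leaves the size open). Compound 4 is expected at 100000 nM, with an estimated range from 50000 nM to 200000 nM.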

Compound 4, half-maximal cytotoxic concentration: > 100000 nM
Compound 4: only a limit was reported (the forecaster's own chance of this, stated with the estimate: 85%); the middle value sits exactly at the limit.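

In this assay compound 4 gives > 100000 nM, which is a limit of the assay and not a number. No step between compound 4 and compound 1, compound 2 or compound 3 can be read, because all the results stop at one limit: the limit of > 100000 nM in this assay, at which 4 of the 4 values shown sit.

The compounds shown leave open whether methyl, bromo or hydrogen on that aromatic carbon makes any difference in this assay.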